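The source may hold more compounds than are shown below. What is called first, only, known or untested is meant among the compounds shown, and "the series" means these compounds.

In a functional assay on PC-3 cells (Homo sapiens) for inhibition, read by MTT assay, with a stated time of 48 h (on this read-out higher numbers stand for weaker inhibition and lower numbers for stronger inhibition), three compounds that carry the shared core have been tested and none of them gives a number. Compound 1 `O=Cc1cccc(OCc2cn(Cc3ccccc3)nn2)c1` reaches only the limit > 50000 nM. Compound 2 `O=C1Nc2ccc(Cl)cc2/C1=C/c1cccc(OCc2cn(Cc3ccccc3)nn2)c1` likewise stops at the limit > 50000 nM. Compound 3 `O=C1Nc2ccc([N+](=O)[O-])cc2/C1=C\c1cccc(OCc2cn(Cc3ccccc3)nn2)c1` also returns only the limit > 50000 nM, so it stands exactly where the other two stand, at the limit of > 50000 nM in this assay, at which 3 of the 3 values shown sit. Compound 4 `COc1ccc(Cc2ccc3c(c2)/C(=C\c2cccc(OCc4cn(Cc5ccccc5)nn4)c2)C(=O)N3)cc1` differs from compound 3 by 4-methoxybenzyl in place of nitro on an aromatic carbon. Among the measured compounds shown here, no measured step exists to guide the change, so the step expected in this assay is an at least 1.6-fold lower number from compound 3 to compound 4 (0.22 log units; that floor lies within the scatter), most likely nothing beyond the scatter. Compound 4 is therefore estimated at 30000 nM, within 5000 nM to 100000 nM, with a fair chance that again only a limit is recorded.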

Compound 4, half-maximal inhibitory concentration: 32200 nM
Compound 4: middle estimate off by 1.1-fold (0.03 log units), on the low side, and the stated range covers the measured number.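

In this assay, replacing nitro with 4-methoxybenzyl on this aromatic carbon gives an at least 1.5-fold lower number from compound 3 to compound 4 (0.19 log units; that floor lies within the scatter). Going by these compounds, this step is only a floor, as compound 3 stands at a limit, so its true size stays unknown. Compound 4 is the first compound here to give a number instead of a limit: the limit of > 50000 nM in this assay, at which 3 of the 4 values shown sit.

The compounds shown leave open whether the aromatic ring of 4-methoxybenzyl, its methoxy or the loss of nitro accounts for this. A plain benzyl, an amine or a carboxylic acid at this place could separate these possibilities.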